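A few compounds are considered here, and "the series" means these few. Any claim that something is new, unique, unknown or untested is made for them only; others in the source may bear on it.

In a functional assay on ZR-75-1 cells (Homo sapiens) for cytotoxicity, read by MTT assay (on this read-out higher numbers stand for weaker inhibition and lower numbers for stronger inhibition), only limits are at hand so far. Compound 1 (`COc1cc2ncnc(Nc3cc(O)[nH]n3)c2cc1OC`) gives < 100000 nM as a limit and not a number. Compound 2 (`COc1cc2ncnc(Nc3cc(-c4ccccc4)[nH]n3)c2cc1OC`) gives < 100000 nM as a limit too. Compound 3 (`COc1cc2ncnc(Nc3cc(-c4ccc(F)cc4)[nH]n3)c2cc1OC`) gives < 100000 nM as a limit as well. It therefore shares the position of the whole series: the limit of < 100000 nM in this assay, at which 3 of the 3 values shown sit, sums it up. Compound 4 (`COc1cc2ncnc(Nc3cc(-c4ccc(Cl)cc4)[nH]n3)c2cc1OC`) carries chloro in place of fluoro on an aromatic carbon relative to compound 3 (chloro in place of fluoro on an aromatic carbon). Fluoro in place of hydrogen gave a step that the two limits leave unreadable from compound 2 to compound 3 while 4-fluorophenyl in place of hydroxy gave a step that the two limits leave unreadable from compound 1 to compound 3 and phenyl in place of hydroxy gave a step that the two limits leave unreadable from compound 1 to compound 2 so none offers a size. No change beyond the scatter is expected, and no direction is favoured: the estimate is a step that the limit leaves unreadable from compound 3 to compound 4 and nothing more. Compound 4 is estimated at 50000 nM with an expected range from 10000 nM to 100000 nM and may well return only a limit again.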

Compound 4, half-maximal inhibitory concentration: < 100000 nM
Compound 4 was reported as a limit; the forecaster's own chance of this, stated with the estimate: 85%; the middle value is on the limit's open side.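

The steps from compound 1, compound 2 and compound 3 to compound 4 cannot be read in this assay, as all four compounds sit at one limit: the limit of < 100000 nM in this assay, at which 4 of the 4 values shown sit.

The compounds shown leave open how strongly each one actually inhibits, and whether any of these substitutions changes that.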